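The source may report more compounds than this note shows. Statements on the series, on what has been measured and on what is new or still open speak of the compounds shown alone.

For the measured compounds named here, compound 1, `COc1nsnc1C(=O)Nc1cc(C(F)(F)F)cc(C(F)(F)F)c1`, stands second highest of the three numbers measured so far in an assay on isolated protein for inhibition of mitogen-activated protein kinase kinase kinase 14 (Homo sapiens), read by ADP-Glo, with a stated time of 60 min, tested at 100 uM, in the presence of a further agent that is not named here; on this read-out lower numbers stand for less inhibition and higher numbers for more inhibition at the one concentration tested (going by the name of the read-out); in this assay compound 1 gives -1.9%. Its nearest neighbour is compound 2, `O=C(Nc1cc(C(F)(F)F)cc(C(F)(F)F)c1)c1n[nH]nc1O`, which in this assay gives -9.5%, a step of a number 7.6 percentage points lower from compound 1 to compound 2 (within the scatter). The furthest is compound 3, `O=C(Nc1cc(C(F)(F)F)cc(C(F)(F)F)c1)c1nonc1O`, which in this assay gives 19.3%, a step of a number 21.2 percentage points higher from compound 1 to compound 3 (beyond the scatter). Compound 4, `Cc1c(C(=O)Nc2cc(C(F)(F)F)cc(C(F)(F)F)c2)c(O)nn1C`, has not yet been measured. It differs from compound 1 in one place: a group of 8 heavy atoms (5 carbon, 2 nitrogen, 1 oxygen; one five-membered aromatic ring with 2 hetero atoms) in place of a group of 7 heavy atoms (3 carbon, 2 nitrogen, 1 oxygen, 1 sulfur; one five-membered aromatic ring with 3 hetero atoms), on a carbonyl carbon. Both measured steps from compound 1 bear on this change, since each likewise replaces the ring on the carbonyl carbon with a different five-membered aromatic ring bearing a hydroxy group; one of those steps was within the scatter, the other modest and upward. A step of similar or smaller size is therefore expected, a number 6.9 percentage points higher from compound 1 to compound 4 (within the scatter), possibly upward but not certainly beyond the scatter. Compound 4 is estimated to give 5% in this assay, within a range from -10% to 25%.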

Compound 4, a percentage reported as inhibition, at one concentration (the size of the read-out at that concentration, not a potency): 24.1%
Compound 4: middle estimate off by 19.1 percentage points, on the low side; measured number inside the range.
By their numbers in this assay, from the lowest: compounds 2 and 1 (each within the scatter of the next); then compounds 3 and 4 (each within the scatter of the next).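

In this assay, for the compounds shown here, placing 3-hydroxy-1,5-dimethyl-1H-pyrazol-4-yl on the carbonyl carbon gives a number 26 percentage points higher from compound 1 to compound 4 (beyond the scatter) and a number 33.6 percentage points higher from compound 2 to compound 4 (beyond the scatter), so a second ring, alongside the one in compound 3, now stands clear of compounds 1 and 2. The step of a number 4.8 percentage points higher from compound 3 to compound 4 (within the scatter) does not separate these two rings, even though they differ in their hetero atoms and heavy-atom count, so this place accepts more than one ring type, while compound 2 goes against any rule that a hydroxy-bearing ring is enough. No measurement here accounts for these differences.

From the compounds shown here alone, whether the two methyl groups of compound 4 contribute remains open, as does the effect of an amine or a carboxylic acid in place of its hydroxy group. These numbers come from a single concentration, so the potency of these compounds also remains open.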